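A 4-methoxyphenyl group on the nitro compound

A few compounds are considered here, and "the series" means these few. Any claim that something is new, unique, unknown or untested is made for them only; others in the source may bear on it.

Compounds built on one shared core have been measured in a functional assay on a cell-free system (plasma, Homo sapiens) for inhibition, with Plasma (Rattus norvegicus) as the target; a lower number here means a stronger inhibitor, a higher number a weaker inhibitor. Compound 1 `O=C(O)CCNC(=O)c1cccc(C(=O)Nc2ccc3c(c2)CNCC3)c1` gives 78 nM, compound 2 `COc1ccc(C(CC(=O)O)NC(=O)c2cccc(C(=O)Nc3ccc4c(c3)CNCC4)c2)cc1` gives 17 nM, and compound 3 `O=C(O)CCNC(=O)c1cc(C(=O)Nc2ccc3c(c2)CNCC3)cc([N+](=O)[O-])c1` gives 2300 nM. Compound 3 therefore has the highest number of the three and is the weakest inhibitor among them. It carries nitro in place of hydrogen on an aromatic carbon, and that single difference comes with a 29-fold higher number from compound 1 to compound 3 (1.47 log units; beyond the scatter).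

Compound 4 `COc1ccc(C(CC(=O)O)NC(=O)c2cc(C(=O)Nc3ccc4c(c3)CNCC4)cc([N+](=O)[O-])c2)cc1` differs from compound 3 in one place: 4-methoxyphenyl in place of hydrogen on a saturated chain carbon bound to an amide-type nitrogen and a saturated chain carbon. The same replacement has been measured once, in the compounds without the nitro group, and it gave a 4.6-fold lower number from compound 1 to compound 2 (0.66 log units; beyond the scatter). That modest step, beyond the scatter, is the closest guide available. Going by the values given here, no measured compound yet shows whether the two changes simply add up, so the guide rests on a single example. A drop in the number of similar size is the reasonable expectation, and the expected step is a 4.6-fold lower number from compound 3 to compound 4 (0.66 log units; beyond the scatter). In this assay the estimated value for compound 4 is 500 nM, with an expected range from 150 nM to 1600 nM.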

Compound 4, half-maximal inhibitory concentration: 450 nM
Beside the measured number, compound 4's estimate is 1.1-fold (0.05 log units) above it; measured number inside the range.
By their numbers in this assay, from the lowest: compound 2; then compound 1; then compound 4; then compound 3.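

In this assay, adding the 4-methoxyphenyl group to the nitro compound gives a 5.1-fold lower number from compound 3 to compound 4 (0.71 log units; beyond the scatter), while adding the nitro group to the 4-methoxyphenyl compound gives a 26-fold higher number from compound 2 to compound 4 (1.42 log units; beyond the scatter). The first comparison shows that the gain seen with 4-methoxyphenyl on the saturated chain carbon is not limited to compounds without the nitro group, since its size holds with the nitro group present: the same change on two cores in this assay, a 4.6-fold lower number (0.66 log units; beyond the scatter) from compound 1 to compound 2 and a 5.1-fold lower number (0.71 log units; beyond the scatter) from compound 3 to compound 4, 1.1-fold (0.05 log units) apart, within the scatter of two such steps The second shows the same for the loss that comes with nitro on an aromatic carbon, so across these four compounds the two changes simply add up: the same change on two cores in this assay, a 29-fold higher number (1.47 log units; beyond the scatter) from compound 1 to compound 3 and a 26-fold higher number (1.42 log units; beyond the scatter) from compound 2 to compound 4, 1.1-fold (0.05 log units) apart, within the scatter of two such steps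

Going by these compounds alone, this additive pattern rests on only one pair of changes, so it remains open whether a plain phenyl or a methyl group on the saturated chain carbon would also lower the number, and by how much. As far as these compounds go, it also remains open whether an amine or a methoxy group in place of the nitro group on the aromatic carbon would raise the number as far, and whether such groups would combine with 4-methoxyphenyl in the same additive way.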